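Chain variation on the shared core: toward compound 4

The compounds below may be only part of what the source reports. "The series", "measured", "known", "first", "only" and "open" are said of these compounds alone.

Measured in a functional assay on MCF7 cells (Homo sapiens) for antiproliferative activity; a higher number here means a weaker inhibitor, a lower number a stronger inhibitor:
compound 1 `CCCn1c(Cc2cc(OC)c(OC)c(OC)c2)nc2c(N)nc(F)nc21`: 25100 nM
compound 2 `CCCCCn1c(Cc2cc(OC)c(OC)c(OC)c2)nc2c(N)nc(F)nc21`: 36300 nM
compound 3 `CC[C@H](C)Cn1c(Cc2cc(OC)c(OC)c(OC)c2)nc2c(N)nc(F)nc21`: 43700 nM

Compound 3 carries the highest of the three numbers, yet a 1.2-fold higher number from compound 2 to compound 3 (0.08 log units; within the scatter) and a 1.7-fold higher number from compound 1 to compound 3 (0.24 log units; within the scatter), so all three sit within the scatter of one another. Compound 4 `CC#CCCn1c(Cc2cc(OC)c(OC)c(OC)c2)nc2c(N)nc(F)nc21` differs from compound 3 by but-2-yn-1-yl in place of sec-butyl on a saturated chain carbon bound to an aromatic nitrogen. For the measured compounds named here, no measured step exchanges a saturated chain for one carrying a triple bond. Going by the values given here, the steps that bear on the chain at this place are a 1.4-fold higher number from compound 1 to compound 2 (0.16 log units; within the scatter) and a 1.2-fold higher number from compound 2 to compound 3 (0.08 log units; within the scatter), each within the scatter. Accordingly, no step beyond the scatter is expected for compound 4 in this assay, and the estimate amounts to a 1.2-fold lower number from compound 3 to compound 4 (0.10 log units; within the scatter). Compound 4 is expected to give 35000 nM, within 14000 nM to 90000 nM.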

Compound 4, half-maximal inhibitory concentration: 37200 nM
Beside the measured number, compound 4's estimate is 1.1-fold (0.03 log units) below it; measured number inside the range.
By their numbers in this assay, from the lowest: compounds 1, 2, 4 and 3 (each within the scatter of the next).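

In this assay, a triple bond in the chain at this place moves the number no further than the scatter, whichever saturated chain it is set against (a 1.2-fold lower number from compound 3 to compound 4 (0.07 log units; within the scatter); a 1.0-fold higher number from compound 2 to compound 4 (0.01 log units; within the scatter); a 1.5-fold higher number from compound 1 to compound 4 (0.17 log units; within the scatter)). The but-2-yn-1-yl chain of compound 4 thus stands level with the saturated chains of compound 1, compound 2 and compound 3. Swapping sec-butyl for but-2-yn-1-yl also removes the defined stereocentre without a step beyond the scatter.

Going by these compounds, whether an amine or a carboxylic acid on a saturated chain carbon bound to an aromatic nitrogen would give a step beyond the scatter stays open. No evidence on the cause of this flat result is at hand.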